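The source may hold more compounds than are shown below. What is called first, only, known or untested is meant among the compounds shown, and "the series" means these compounds.

Compound 1 `COc1cc[nH]c1/C=C1\C(=O)Nc2ccc(F)c(C#C[C@H](C)O)c21` gives 400 nM in a functional assay on SW480 cells (Homo sapiens) for inhibition (a lower number here means a stronger inhibitor, a higher number a weaker inhibitor), and stands highest of the two numbers measured, so it is the weaker inhibitor of the pair. Compound 2 `CN[C@H](C#Cc1c(F)ccc2c1/C(=C/c1[nH]ccc1OC)C(=O)N2)CO` gives 100 nM in this assay, and the step of a 4.0-fold lower number from compound 1 to compound 2 (0.60 log units; beyond the scatter) came with a 2-hydroxy-1-(methylamino)ethyl in place of 1-hydroxyethyl on a triple-bonded carbon. Compound 3 `CCN[C@H](C#Cc1c(F)ccc2c1/C(=C/c1[nH]ccc1OC)C(=O)N2)CO` differs from compound 1 by 1-(ethylamino)-2-hydroxyethyl in place of 1-hydroxyethyl on a triple-bonded carbon, a change closely resembling that single measured step. A modest lowering of the number in this assay, about the size of a 4.0-fold lower number from compound 1 to compound 2 (0.60 log units; beyond the scatter), is therefore expected, giving an estimated 3.6-fold lower number from compound 1 to compound 3 (0.56 log units; beyond the scatter). Compound 3 is estimated at 110 nM, within 40 nM to 300 nM.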

Compound 3, half-maximal inhibitory concentration: 566 nM
Compound 3: middle estimate off by 5.1-fold (0.71 log units), on the low side; measured number outside the range, above it.
By their numbers in this assay, from the lowest: compound 2; then compounds 1 and 3 (each within the scatter of the next).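

In this assay, the gain seen with the methylamino group does not carry over to the ethylamino group, as one added methyl gives a 5.7-fold higher number from compound 2 to compound 3 (0.75 log units; beyond the scatter). Against the original 1-hydroxyethyl group, the larger 1-(ethylamino)-2-hydroxyethyl group gives a 1.4-fold higher number from compound 1 to compound 3 (0.15 log units; within the scatter), so the result at this position depends on a small change at the amine nitrogen. Nothing available explains this sensitivity. Still open, on these data alone, is how an unsubstituted amine, with no carbon group on the nitrogen, or a longer propylamino chain would compare.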